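Aryl Group Returns to the Ring Nitrogen of Compound 3

This account rests on a few compounds, and the source may have more. Where it says the series, first, only, none or still open, it means among the compounds named here.

Three compounds have been measured in a functional assay on 143B cells (Homo sapiens) for inhibition, read by CCK-8 assay, with a stated time of 72 h, tested at 1 uM; on this read-out lower numbers stand for less inhibition and higher numbers for more inhibition at the one concentration tested (going by the name of the read-out):
Compound 1 `COc1ccc(F)cc1N1C(=O)CSC1c1cccc(C(=O)NCCCCc2ccccc2)c1` gives 62%.
Compound 2 `Cc1cccc(N2C(=O)CSC2c2cccc(C(=O)NCCCCc3ccccc3)c2)c1` gives 71%.
Compound 3 `CCN1C(=O)CSC1c1cccc(C(=O)NCCCCc2ccccc2)c1` gives 40%.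

Compound 3 stands lowest of the three: from its nearest neighbour the step is a number 22 percentage points lower from compound 1 to compound 3 (beyond the scatter), and from the furthest it is a number 31 percentage points lower from compound 2 to compound 3 (beyond the scatter). Both steps swap an aryl group on the ring nitrogen for ethyl, and both lower the number. Compound 4 `COc1cc(F)ccc1N1C(=O)CSC1c1cccc(C(=O)NCCCCc2ccccc2)c1` reverses that kind of swap: 4-fluoro-2-methoxyphenyl in place of ethyl on an amide-type nitrogen in a ring. The two aryl-bearing analogues differ only within the scatter, as a number 9 percentage points higher from compound 1 to compound 2 (within the scatter) shows, so the size of a return to an aryl group is expected to match the earlier drops. Compound 4 is therefore expected to rise by about a number 23 percentage points higher from compound 3 to compound 4 (beyond the scatter), to an estimated 63%, between 50% and 76%.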

Compound 4, a percentage reported as inhibition, at one concentration (the size of the read-out at that concentration, not a potency): 63%
For compound 4 middle estimate and measured number coincide at the digits printed, and the stated range covers the measured number.
By their numbers in this assay, from the lowest: compound 3; then compounds 1, 4 and 2 (each within the scatter of the next).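

In this assay, a third aryl group on the amide-type nitrogen in a ring again stands clear of ethyl (a number 23 percentage points higher from compound 3 to compound 4 (beyond the scatter)). Among the fluorinated groups, 4-fluoro-2-methoxyphenyl and 5-fluoro-2-methoxyphenyl cannot be told apart (a number 1 percentage points higher from compound 1 to compound 4 (within the scatter)). Nor can 4-fluoro-2-methoxyphenyl and 3-methylphenyl (a number 8 percentage points lower from compound 2 to compound 4 (within the scatter)), so the three aryl groups form one level here.

On these data alone, whether an aminoethyl chain or a carboxylic acid on this nitrogen would reach that level stays open. Nothing at hand explains the gap between the aryl groups and ethyl.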